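Swapping a Sulfone for a Branched Alkyl: Cytotoxicity Outlook

A few compounds are considered here, and "the series" means these few. Any claim that something is new, unique, unknown or untested is made for them only; others in the source may bear on it.

Of the compounds shown here, three have so far been tested in an ADME assay on HeLa cells (Homo sapiens) for cytotoxicity, read by ATP content, with a stated time of 3 days; on this read-out higher numbers stand for lower toxicity in this test and lower numbers for higher toxicity in this test. For the measured compounds named here, compound 1 `CS(=O)(=O)c1ccc(-n2c(=O)n(Cc3cc4cc(Cl)ccc4n3CCCC#N)c3cnccc32)cc1` is the first of them. In this assay compound 1 reaches only the limit of the test, reported as > 50000 nM. Compound 2 `O=c1n(Cc2nc3nc(Cl)ccc3n2CCCCO)c2cnccc2n1C1CC1` carries the shared core of the compounds that follow. In this assay compound 2 likewise gives only a limit, > 50000 nM. Compound 3 `CS(=O)(=O)CCCn1c(Cn2c(=O)n(C3CC3)c3ccncc32)nc2nc(Cl)ccc21` differs from compound 2 in a single place: methylsulfonyl in place of hydroxymethyl on a saturated chain carbon, three bonds along the chain from an aromatic nitrogen. In this assay compound 3 again gives a limit, > 50000 nM. The step that the two limits leave unreadable from compound 2 to compound 3 therefore cannot be sized, since both of its ends are limits. The whole picture so far is the limit of > 50000 nM in this assay, at which 3 of the 3 values shown sit.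

Compound 4 `CC(C)CCn1c(Cn2c(=O)n(C3CC3)c3ccncc32)nc2nc(Cl)ccc21` is not yet measured. It differs from compound 3 by isopropyl in place of (methylsulfonyl)methyl on a saturated chain carbon, two bonds along the chain from an aromatic nitrogen. Going by the values given here, the only measured step on this chain is unreadable, so no measured step gives a direction for the new change. For compound 4 the step that the limit leaves unreadable from compound 3 to compound 4 is expected to stay within the scatter. The estimate for compound 4 in this assay is 60000 nM, within a range from 20000 nM to 150000 nM.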

Compound 4, half-maximal cytotoxic concentration: > 50000 nM
Compound 4: no number, only a limit; the forecaster's own chance of this, stated with the estimate: 70%; the middle value lies beyond the limit too.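

No size can be read for the steps from compound 2 and from compound 3 to compound 4, because every value shown is a limit of the test and not a number: the limit of > 50000 nM in this assay, at which 4 of the 4 values shown sit. The compounds shown leave open how far each lies beyond that limit, and whether changing the chain group alters this read-out at all.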